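The source may report more compounds than this note shows. Statements on the series, on what has been measured and on what is new or still open speak of the compounds shown alone.

Working notes on the series.

Compound 1 `Cn1nccc1-c1ccccc1NCC1=NCCN1` and compound 2 `CCn1nccc1-c1ccccc1NCC1=NCCN1` share one core and differ only in the chain on the aromatic nitrogen. In an in vitro functional assay on cells (Fibroblast) for agonist activity at Alpha-1B adrenergic receptor (Homo sapiens) (on this read-out lower numbers stand for an effect already at smaller amounts and higher numbers for an effect only at larger amounts of compound), compound 1 gives < 100000 nM, which is a limit of the assay and not a number. In this assay compound 2 likewise gives < 100000 nM, again a limit. The step that the two limits leave unreadable from compound 1 to compound 2 therefore cannot be sized; the limit of < 100000 nM in this assay, at which 2 of the 2 values shown sit, is all that the two values show, so compound 2 stands nowhere more exactly than at that limit.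

Compound 3 `CCCn1nccc1-c1ccccc1NCC1=NCCN1` extends the chain once more: methyl in place of hydrogen on a saturated chain carbon, two bonds along the chain from an aromatic nitrogen. For the measured compounds named here, the one measured step that bears on it, from compound 1 to compound 2, is unreadable, so no size or direction can be read for the step to compound 3. The expectation for compound 3 in this assay is therefore set at 5000 nM, within a range from 200 nM to 80000 nM, which means an expected step that the limit leaves unreadable from compound 2 to compound 3 relative to compound 2.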

Compound 3, half-maximal effective concentration: < 100000 nM
Compound 3: only a limit was reported (the forecaster's own chance of this, stated with the estimate: 50%); the middle value is on the limit's open side.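

For the compounds shown here, no step among compound 1, compound 2 and compound 3 can be read in this assay, so compound 3 adds no new step: the limit of < 100000 nM in this assay, at which 3 of the 3 values shown sit.

The compounds shown leave open whether the chain on the aromatic nitrogen affects the read-out at all, and in which direction.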